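Removing a methoxy group on an aryl lipase inhibitor

This account rests on a few compounds, and the source may have more. Where it says the series, first, only, none or still open, it means among the compounds named here.

Three compounds have been measured in an assay on HEK293 cells for inhibition of Monoacylglycerol lipase ABHD6 (Homo sapiens), with stated times of 30 min and 5 min; on this read-out higher numbers stand for weaker inhibition and lower numbers for stronger inhibition:

compound 1 `COc1ccc(-c2cn(Cc3ccc(F)cc3)c(=O)c(C(=O)NC3CCCCCC3)c2C)cc1` gives > 10000 nM
compound 2 `O=C(NC1CCCCCC1)c1c(-c2ccccc2)c(Br)cn(Cc2ccc(F)cc2)c1=O` gives 3000 nM
compound 3 `COc1ccc(-c2c(Br)cn(Cc3ccc(F)cc3)c(=O)c2C(=O)NC2CCCCCC2)cc1` gives > 10000 nM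

The value of compound 1 is a limit of the assay and not a number. The value of compound 3 is likewise a limit. Compounds 2 and 3 differ in one place, (hydrogen in place of methoxy on an aromatic carbon), and this gave an at least 3.3-fold lower number from compound 3 to compound 2 (0.52 log units; beyond the scatter). That step is known only as a bound, since compound 3 sits at the limit of > 10000 nM in this assay, at which 2 of the 3 values shown sit.

Compound 4 `Cc1c(-c2ccccc2)cn(Cc2ccc(F)cc2)c(=O)c1C(=O)NC1CCCCCC1` is not yet measured in this assay. It differs from compound 1 by hydrogen in place of methoxy on an aromatic carbon, the same change as from compound 3 to compound 2. The difference between the cores of compound 1 and compound 3 is not broken down here.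

Going by the values given here, for compound 4 a step of an at least 2.5-fold lower number from compound 1 to compound 4 (0.39 log units; beyond the scatter) is expected, of similar direction to the one seen from compound 3 to compound 2, resting on the step of an at least 3.3-fold lower number from compound 3 to compound 2 (0.52 log units; beyond the scatter). Compound 4 is therefore estimated at 4000 nM, between 1500 nM and 12000 nM.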

Compound 4, half-maximal inhibitory concentration: > 10000 nM
Compound 4: no number, only a limit (the forecaster's own chance of this, stated with the estimate: 35%); middle value at least 2.5-fold (0.39 log units) from the limit.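

In this assay, going by these compounds alone, compound 4, like compound 1, gives only a limit of the assay and not a number, so no step between compound 1 and compound 4 can be read: the limit of > 10000 nM in this assay, at which 3 of the 4 values shown sit. The compounds shown leave open whether going from 4-methoxyphenyl to phenyl lowers the number at all on the core of compound 1.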